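Swapping a cyclopentenyl for a pyrimidinyl on the shared core

A few compounds are considered here, and "the series" means these few. Any claim that something is new, unique, unknown or untested is made for them only; others in the source may bear on it.

Measured so far in an assay on isolated protein for antagonist activity at prostaglandin E2 receptor EP1 subtype (Homo sapiens), read by reporter gene assay; on this read-out higher numbers stand for weaker inhibition and lower numbers for stronger inhibition:
- compound 1 `O=C(O)c1csc(-n2nc(-c3ccc(F)cc3)c3ccccc32)n1`: 4.5 nM
- compound 2 `COc1ccc(-c2nn(-c3nc(C(=O)O)cs3)c3ccccc23)cc1`: 4 nM
- compound 3 `O=C(O)c1csc(-n2nc(C3=CCCC3)c3ccccc32)n1`: 80 nM

Compound 3 gives the highest number of the three, so it is the weakest inhibitor here. The other two sit close together: the step of a 1.1-fold lower number from compound 1 to compound 2 (0.05 log units; within the scatter) lies within the scatter. Against that, an 18-fold higher number from compound 1 to compound 3 (1.25 log units; beyond the scatter) and a 20-fold higher number from compound 2 to compound 3 (1.30 log units; beyond the scatter) are both large steps in the same direction, so replacing an aromatic ring with the cyclopentenyl ring costs a great deal.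

Compound 4 `O=C(O)c1csc(-n2nc(-c3cncnc3)c3ccccc32)n1` reverses that kind of change: pyrimidin-5-yl in place of cyclopent-1-en-1-yl on an aromatic carbon. Among the compounds with values here, the pyrimidinyl ring restores an aromatic six-membered ring in the position where compound 1 and compound 2 carry theirs, so on the two large steps just named a return toward their numbers in this assay is expected, with some allowance made for the two ring nitrogens, whose effect no measured pair shows. The estimate for compound 4 is therefore 12 nM, between 3 nM and 50 nM, a step of a 6.7-fold lower number from compound 3 to compound 4 (0.82 log units; beyond the scatter) that is expected to be downward and beyond the scatter.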

Compound 4, half-maximal inhibitory concentration: > 100 nM
Compound 4 ended at the assay's limit (the forecaster's own chance of this, stated with the estimate: 2%); middle value at least 8.3-fold (0.92 log units) from the limit.
By their numbers in this assay, from the lowest: compounds 2 and 1 (each within the scatter of the next); then compound 3. At a limit, above all of these: compound 4.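

Compound 4 stands at a limit of this assay, so its result is a bound and not a number: the limit of > 100 nM in this assay, at which 1 of the 4 values shown sits.

Having an aromatic six-membered ring at this position is clearly not enough on its own, since compound 1 and compound 2 carry one there too, yet the steps are large: an at least 22-fold higher number from compound 1 to compound 4 (1.34 log units; beyond the scatter) and an at least 25-fold higher number from compound 2 to compound 4 (1.39 log units; beyond the scatter). Replacing cyclopent-1-en-1-yl with pyrimidin-5-yl gives an at least 1.2-fold higher number from compound 3 to compound 4 (0.09 log units; that floor lies within the scatter), so there is no return toward the two lower numbers, though this floor does not set the two compounds clearly apart.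

The compounds shown cannot separate the part played by the ring nitrogens from the part played by the missing substituent on the ring. An unsubstituted phenyl or a pyridin-3-yl at this position would bear directly on that question, and so would a pyrimidin-5-yl carrying a methoxy group.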